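This account rests on a few compounds, and the source may have more. Where it says the series, first, only, none or still open, it means among the compounds named here.

Two compounds in the series carry a measurement in a functional assay on K562 cells (Homo sapiens) for inhibition, read by trypan blue exclusion, with a stated time of 72 h; on this read-out lower numbers stand for stronger inhibition and higher numbers for weaker inhibition. Compound 1 `Cc1ccc(S(=O)(=O)c2cc3cnc(Nc4cccc5cccnc45)nc3n(C)c2=O)cc1` gives 10000 nM. Compound 2 `CCCn1c(=O)c(S(=O)(=O)c2ccc(F)cc2F)cc2cnc(Nc3ccc4[nH]ccc4c3)nc21` gives 1000 nM, the lowest of the two numbers; compound 1 is its nearest neighbour, and the gap between them lies beyond the scatter. Compound 3 `O=c1c(S(=O)(=O)c2ccc(F)cc2F)cc2cnc(Nc3ccc4[nH]ccc4c3)nc2n1C1CCCC1` is not yet measured. It differs from compound 2 in one place: cyclopentyl in place of propyl on an aromatic nitrogen. Going by the values given here, no measured pair shows this change, so only a small step is expected, within the scatter, in either direction. Compound 3 is estimated at 700 nM in this assay, with a range of 250 nM to 2000 nM, which means an expected step of a 1.4-fold lower number from compound 2 to compound 3 (0.15 log units; within the scatter).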

Compound 3, half-maximal inhibitory concentration: 5000 nM
The estimate for compound 3 lay 7.1-fold (0.85 log units) below the measured number; measured number outside the range, above it.
By their numbers in this assay, from the lowest: compound 2; then compounds 3 and 1 (each within the scatter of the next).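

In this assay, the group on the aromatic nitrogen matters for inhibition: cyclopentyl in place of propyl gives a 5.0-fold higher number from compound 2 to compound 3 (0.70 log units; beyond the scatter), with the rest of the structure unchanged. Going by these compounds alone, this is the only step read at this position, and it runs towards weaker inhibition. Nothing measured here accounts for this step. One pair cannot separate the effect of the ring from that of the added carbons. Going by these compounds, a butyl chain or a cyclobutyl ring on this nitrogen stays open, as does whether the step holds with other groups elsewhere on the core.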